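Aryl ring swap on the amide nitrogen of a TRPM8 agonist

This account rests on a few compounds, and the source may have more. Where it says the series, first, only, none or still open, it means among the compounds named here.

Compound 1 `Cc1ccc(OCC(=O)N(Cc2cccs2)c2ccnn2C)cc1`: 422 nM
Compound 2 `CCN(Cc1cccs1)C(=O)CCc1ccc(C)cc1`: 93 nM

In an assay on HEK293 cells for agonist activity at transient receptor potential cation channel subfamily M member 8 (Homo sapiens), read by fluorescence and calcium flux, with a stated time of 15 min (a lower number here means that less compound is needed, a higher number that more compound is needed for the effect), compound 1 gives 422 nM, the higher of the two numbers measured; compound 2, which shares the thienylmethyl amide but differs in several places, gives 93 nM, a gap beyond the scatter. Among the compounds with values here, no single-point step is known between them. Compound 3 `Cc1ccc(OCC(=O)N(Cc2cccs2)c2cnccn2)cc1` differs from compound 1 in one place: pyrazin-2-yl in place of 1-methyl-1H-pyrazol-5-yl on an amide-type nitrogen. Both groups carry the same count of atoms and acceptors, so the step is expected to fall within the scatter, with no clear direction. Compound 3 is estimated at 500 nM, between 150 nM and 1700 nM, which means an expected step of a 1.2-fold higher number from compound 1 to compound 3 (0.07 log units; within the scatter).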

Compound 3, half-maximal effective concentration: 1240 nM
Beside the measured number, compound 3's estimate is 2.5-fold (0.39 log units) below it; low and high end bracket the measured number.
By their numbers in this assay, from the lowest: compound 2; then compound 1; then compound 3.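

In this assay the amide-type nitrogen proves sensitive to which ring it carries: pyrazin-2-yl in place of 1-methyl-1H-pyrazol-5-yl gives a 2.9-fold higher number from compound 1 to compound 3 (0.47 log units; beyond the scatter) even though both groups have the same counts of heavy atoms, donors and acceptors. These counts alone therefore do not settle the number at this position. No measurement shown here gives a reason for the step. The compounds shown leave open whether a phenyl or a pyridin-2-yl group on this nitrogen would give a lower number than compound 1 does.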